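Replacing a methyl with a methylazetidinyl ring: solubility outlook

The source may hold more compounds than are shown below. What is called first, only, known or untested is meant among the compounds shown, and "the series" means these compounds.

Measured so far:
compound 1, `CN1CCC(CNS(=O)(=O)c2ccccc2Nc2cc(-c3ccc4ccn(C)c4c3)c3nccnc3c2)C1`, 35 ug/mL;
compound 2, `CN1CCC(NS(=O)(=O)c2ccccc2Nc2cc(-c3ccc4ccn(C)c4c3)c3nccnc3c2)C1`, 26 ug/mL;
compound 3, `CNC(=O)c1ccncc1Nc1cc(-c2ccc3ccn(C)c3c2)c2nccnc2c1`, 4 ug/mL.

The read-out throughout is a physicochemical assay for solubility, read by spectrophotometry, measured as kinetic solubility, at pH 8, tested at 500 uM; a lower number here means a less soluble compound, a higher number a more soluble compound. Compound 3 stands lowest of the three numbers: compound 2 is nearest to it and compound 1 furthest, both beyond the scatter.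

Compound 4, `CN1CC(NC(=O)c2ccncc2Nc2cc(-c3ccc4ccn(C)c4c3)c3nccnc3c2)C1`, is not yet measured. It differs from compound 3 in one place: 1-methylazetidin-3-yl in place of methyl on an amide-type nitrogen.

Within the data shown here, only one measured step is available, and it bears on this change loosely. Between compound 1 and compound 2 the group on a sulfonamide nitrogen changes from (1-methylpyrrolidin-3-yl)methyl to 1-methylpyrrolidin-3-yl, and the result is a 1.3-fold lower number from compound 1 to compound 2 (0.13 log units; within the scatter). Among the measured compounds shown here, no step links compound 3 to compound 1 or compound 2; their values merely show that the two compounds carrying a 1-methylpyrrolidin-3-yl unit sit well above compound 3. Compound 4 likewise gains a ring with a nitrogen, the 1-methylazetidin-3-yl, in place of a methyl. For the measured compounds named here, on this thin evidence a rise is expected rather than a fall, of a size estimated as a 5.0-fold higher number from compound 3 to compound 4 (0.70 log units; beyond the scatter), though the single bearing step was within the scatter. Compound 4 is therefore estimated at 20 ug/mL, with a range from 6 ug/mL to 60 ug/mL.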

Compound 4, solubility: 170 ug/mL
For compound 4 the middle estimate is 8.5-fold (0.93 log units) below the measured one; measured number outside the range, above it.
By their numbers in this assay, from the lowest: compound 3; then compounds 2 and 1 (each within the scatter of the next); then compound 4.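

On an amide-type nitrogen, 1-methylazetidin-3-yl in place of methyl gives, in this assay, a 43-fold higher number from compound 3 to compound 4 (1.63 log units; beyond the scatter) and so is a large step well beyond the scatter. Among these compounds, the only earlier step, on a sulfonamide nitrogen, stayed within the scatter, so this is the first sign in these compounds that the group carried on such a nitrogen can move this read-out strongly. No measurement shown here explains why the number rises so far.

The change brings in several things at once, as four more carbons, one nitrogen and a four-membered non-aromatic ring arrive together, so the step belongs to the whole group and cannot yet be divided among its parts. A cyclobutyl group on the same nitrogen would test the ring without its nitrogen, and an open-chain amine such as 2-(dimethylamino)ethyl would test the nitrogen without the ring, which leaves open whether either one alone would reach a similar number.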